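Stereochemistry in the cyclohexane-1,3-diamide series

A few compounds are considered here, and "the series" means these few. Any claim that something is new, unique, unknown or untested is made for them only; others in the source may bear on it.

The series is built on a cyclohexane diamide core carrying a picolinamide and a 3-cyanobenzamide. Compound 1 `N#Cc1cccc(C(=O)NC2CCCC(NC(=O)c3ccccn3)C2)c1` is drawn without configuration at either ring centre and gives 531 nM in a functional assay on HEK293 cells for antagonist activity at metabotropic glutamate receptor 5 (Homo sapiens), read by FLIPR and calcium flux; a lower number here means a stronger inhibitor, a higher number a weaker inhibitor. Compound 2 `O=C(Cc1ccccn1)N[C@H]1CCC[C@H](NC(=O)c2cccc(Cl)c2)C1` belongs to a different amide pairing. In this assay compound 2 reaches only the limit > 10000 nM, not a number. Compound 3 `N#Cc1cccc(C(=O)N[C@@H]2CCC[C@H](NC(=O)c3ccccn3)C2)c1` is the same atoms and bonds as compound 1 with both centres defined. In this assay compound 3 is likewise reported only as the limit > 10000 nM. The step of an at least 18-fold higher number from compound 1 to compound 3 (1.27 log units; beyond the scatter) is large; it is read in the light of the fact that one of compounds 1 and 3 is drawn with a defined configuration and the other without, at the place where they differ and of the limit of > 10000 nM in this assay, at which 2 of the 3 values shown sit.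

Compound 4 `N#Cc1cccc(C(=O)N[C@@H]2CCC[C@@H](NC(=O)c3ccccn3)C2)c1` differs from compound 3 as follows: the two compounds have the same atoms and bonds and differ only in configuration as drawn: 1 of 2 stereo elements differ; a stereocentre at a saturated ring carbon is drawn S in compound 3 and R in compound 4. Within the data shown here, the only measured step that bears on this change is the one from compound 1 to compound 3, and it shows that configuration at these ring centres moves the number by a large amount. Compound 4 is therefore expected to give a lower number than compound 3, with the step of an at least 11-fold lower number from compound 3 to compound 4 (1.04 log units; beyond the scatter) as the estimate. For compound 4 the expected value in this assay is 900 nM, within 150 nM to 8000 nM.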

Compound 4, half-maximal inhibitory concentration: 231 nM
The estimate for compound 4 lay 3.9-fold (0.59 log units) above the measured number; the range from low to high includes it.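

In this assay, the step of an at least 43-fold lower number from compound 3 to compound 4 (1.63 log units; beyond the scatter) comes from a single ring carbon changing from S to R, with nothing else altered, so one centre alone is enough to separate a measurable inhibitor from an inactive drawing of the same atoms: the fact that compounds 3 and 4 differ only in the configuration as drawn. The value of compound 3, > 10000 nM, is a limit and not a number, so this step gives only a minimum size. The step of a 2.3-fold lower number from compound 1 to compound 4 (0.36 log units; beyond the scatter) is modest but beyond the scatter, and it shows that a defined form can give a lower number than the drawing without configuration, a direction that the earlier step from the same undefined compound did not reveal: the fact that one of compounds 1 and 4 is drawn with a defined configuration and the other without, at the place where they differ.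

The effect of changing the other ring carbon with this amide pairing remains open, as the compounds shown cover only two defined arrangements of the two centres. It is also unknown whether the same configuration would be preferred with a carboxylic acid or a primary amine in place of the nitrile.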